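This account rests on a few compounds, and the source may have more. Where it says the series, first, only, none or still open, it means among the compounds named here.

Measured so far:
compound 1, `Cc1cccc(Nc2ncccc2OCc2ccccc2)n1`, 870 nM
compound 2, `CCOc1cc(-c2cccc(F)c2)cnc1Nc1cccc(C)n1`, 126 nM

Within the data shown here, in an assay on Ltk cells with metabotropic glutamate receptor 5 (Homo sapiens) as the target, read by fluorescence and calcium flux (a lower number here means a stronger inhibitor, a higher number a weaker inhibitor), compound 2 gives 126 nM, the lower of the two numbers; its only neighbour here, compound 1, gives 870 nM, a higher number that lies beyond the usual scatter. Compound 3, `CCOc1cc(-c2cccnc2C#N)cnc1Nc1cccc(C)n1`, has not been measured. It differs from compound 2 in one place: 2-cyanopyridin-3-yl in place of 3-fluorophenyl on an aromatic carbon. Among the measured compounds shown here, no measured pair shows the effect of this kind of exchange, so the direction of the step is uncertain, and no change beyond the scatter is assumed. The step from compound 2 to compound 3 is expected to be a 1.2-fold higher number from compound 2 to compound 3 (0.08 log units; within the scatter). Compound 3 is estimated at 150 nM in this assay, within a range from 40 nM to 600 nM.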

Compound 3, half-maximal inhibitory concentration: 80 nM
Estimate against measurement, compound 3: 1.9-fold (0.27 log units) above; the measured number falls inside the stated range.
By their numbers in this assay, from the lowest: compounds 3 and 2 (each within the scatter of the next); then compound 1.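

Within this assay the exchange of 3-fluorophenyl for 2-cyanopyridin-3-yl gives a 1.6-fold lower number from compound 2 to compound 3 (0.20 log units; within the scatter) and the two numbers cannot be told apart. This position, para to the (6-methylpyridin-2-yl)amino group, therefore accepts a six-membered aromatic ring carrying a ring nitrogen and a nitrile as well as one of carbon only, with fluorine. As far as these compounds go, whether a group without an aromatic ring, such as an amine or a carboxylic acid, would fit here stays open. Nothing at hand says what lies behind this result.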